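From methyl to cyclopropyl, starting from a limit

The source may report more compounds than this note shows. Statements on the series, on what has been measured and on what is new or still open speak of the compounds shown alone.

In an ADME assay on HCT-116 cells (Homo sapiens) for cytotoxicity, read by CellTiter-Glo, with a stated time of 72 h (a lower number here means a stronger inhibitor, a higher number a weaker inhibitor), compound 3 (`Cc1nc(Cl)sc1S(=O)(=O)N1CCC(N2CCC(C)CC2)CC1`) gives > 10000 nM, which is a limit and not a number. Compound 1 (`CC1CCN(C2CCN(S(=O)(=O)c3cnc(Cl)s3)CC2)CC1`) gives > 10000 nM, also a limit. Compound 2 (`CC1CCN(C2CCN(S(=O)(=O)c3cccc(Cl)c3)CC2)CC1`) gives > 5000 nM, again a limit. Compound 4 (`CC1CCN(C2CCN(S(=O)(=O)c3sc(Cl)nc3C3CC3)CC2)CC1`) is not yet measured and carries cyclopropyl in place of methyl on an aromatic carbon. The closest measured change, methyl in place of hydrogen on an aromatic carbon, is a step that the two limits leave unreadable from compound 1 to compound 3. It therefore offers no size or direction to carry over. The expected step is a number no higher from compound 3 to compound 4 (the limit leaves the size open), with no change expected beyond the scatter. The estimated value for compound 4 is 10000 nM, within a range of 3000 nM to 30000 nM.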

Compound 4, half-maximal inhibitory concentration: > 10000 nM
Compound 4: only a limit was reported (the forecaster's own chance of this, stated with the estimate: 80%); the middle value sits exactly at the limit.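

In this assay compound 4 gives > 10000 nM, a limit and not a number, and its steps from compound 1 and compound 3 cannot be read. The compounds shown leave open how hydrogen, methyl and cyclopropyl on that aromatic carbon compare.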